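A few compounds are considered here, and "the series" means these few. Any claim that something is new, unique, unknown or untested is made for them only; others in the source may bear on it.

Measured compounds in a functional assay on COR-L23 cells (Homo sapiens) for antiproliferative activity, read by CellTiter-Glo, with a stated time of 72 h; on this read-out lower numbers stand for stronger inhibition and higher numbers for weaker inhibition:
- compound 1 `O=C(Nc1ccc(CN2Cc3ccccc3C2=O)cc1)N1CCC(c2cccnc2)C1`; compound 1 returns only a limit of the assay, > 2500 nM; > 2500 nM (2 entries)
- compound 2 `C[C@@H](c1ccc(NC(=O)N2CC(c3cccnc3)C2)cc1)N1Cc2ccccc2C1=O`; compound 2 gives 8 nM
- compound 3 `C[C@@H](c1ccc(NC(=O)N2CC(c3ccc(N)nc3)C2)cc1)N1Cc2ccccc2C1=O`; compound 3 gives 19 nM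

Compound 3 holds the higher of the two numbers; its nearest neighbour is compound 2, the step being a 2.4-fold higher number from compound 2 to compound 3 (0.38 log units; beyond the scatter). Compound 4 `C[C@H](NC(=O)C1CCOCC1)c1ccc(NC(=O)N2CC(c3ccc(N)nc3)C2)cc1` alters a different place: a group of 9 heavy atoms (6 carbon, 1 nitrogen, 2 oxygen; one six-membered non-aromatic ring with 1 hetero atom) in place of a group of 10 heavy atoms (8 carbon, 1 nitrogen, 1 oxygen; one five-membered non-aromatic ring with 1 hetero atom, one six-membered aromatic ring of carbon only), on a saturated chain carbon bound to an aromatic carbon and a saturated chain carbon. Among the measured compounds shown here, no measured step touches this position; the one step available, a 2.4-fold higher number from compound 2 to compound 3 (0.38 log units; beyond the scatter), concerns the amino on the aromatic carbon and carries no direct information here. Because compound 1, which lacks the methyl-bearing arrangement, gives only > 2500 nM; > 2500 nM (2 entries), a step of a 16-fold higher number from compound 3 to compound 4 (1.20 log units; beyond the scatter) toward weaker inhibition is expected. Compound 4 is estimated at 300 nM, within 50 nM to 2500 nM.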

Compound 4, half-maximal inhibitory concentration: 110 nM
Beside the measured number, compound 4's estimate is 2.7-fold (0.44 log units) above it; measured number inside the range.
By their numbers in this assay, from the lowest: compound 2; then compound 3; then compound 4.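

In this assay, among the compounds shown here, ((oxan-4-yl)carbonyl)amino on the saturated chain carbon bound to an aromatic carbon and a saturated chain carbon gives the first measured step at this position (a 5.8-fold higher number from compound 3 to compound 4 (0.76 log units; beyond the scatter)). The change leaves a number rather than a limit, so this position accepts a group with no aromatic ring of carbon only, though inhibition is weaker beyond the scatter. No measurement at hand accounts for the size of this step.

Still open, on these data alone, is how a piperidine amide or a simple acetamide would compare at this place. Also open, as far as these compounds go, is whether the step for the amino on the aromatic carbon holds with ((oxan-4-yl)carbonyl)amino present.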